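The source may report more compounds than this note shows. Statements on the series, on what has been measured and on what is new or still open speak of the compounds shown alone.

Measured so far in a functional assay on K562 cells (Homo sapiens) for cytotoxicity, read by sulforhodamine B assay; a lower number here means a stronger inhibitor of growth, a higher number a weaker inhibitor of growth:
- compound 1 `CC1=CC[C@@H]([C@@](C)(O)CCCC(C)(C)NC(=S)N/N=C\c2ccccc2)CC1`: 130 nM
- compound 2 `COc1ccc(/C=N\NC(=S)NC(C)(C)CCC[C@](C)(O)[C@@H]2CC=C(C)CC2)cc1`: 220 nM
- compound 3 `CC1=CC[C@@H]([C@@](C)(O)CCCC(C)(C)NC(=S)N/N=C\c2cccc(Cl)c2)CC1`: 30 nM

Of these three, compound 3 has the lowest number, at 30 nM, and so is the strongest growth inhibitor here. The next compound, compound 4 `CC1=CC[C@@H]([C@@](C)(O)CCCC(C)(C)NC(=S)N/N=C\c2ccc(Cl)cc2)CC1`, has the same atoms joined differently: 4-chlorophenyl in place of 3-chlorophenyl on a carbon with a double bond to nitrogen. In words, 4-chlorophenyl takes the place of 3-chlorophenyl on a carbon with a double bond to nitrogen.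

Among the measured compounds shown here, three measured steps bear on this. Chloro in place of hydrogen gave a 4.3-fold lower number from compound 1 to compound 3 (0.64 log units; beyond the scatter), whereas methoxy in place of hydrogen gave a 1.7-fold higher number from compound 1 to compound 2 (0.23 log units; within the scatter). The swap of 4-methoxyphenyl for 3-chlorophenyl gave a 7.3-fold lower number from compound 2 to compound 3 (0.87 log units; beyond the scatter). For the measured compounds named here, no measured pair compares the two chlorophenyl groups directly, so any forecast is uncertain. Chloro should keep much of its benefit, but the only group named with a 4 so far belongs to compound 2, at 220 nM, which points to a slightly higher number. The expected move is small and upward: a 1.7-fold higher number from compound 3 to compound 4 (0.22 log units; within the scatter). For compound 4, the estimate is 50 nM, with an expected range from 18 nM to 130 nM.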

Compound 4, concentration for 50% growth inhibition: 40 nM
Estimate against measurement, compound 4: 1.3-fold (0.10 log units) above, and the stated range covers the measured number.
By their numbers in this assay, from the lowest: compounds 3 and 4 (each within the scatter of the next); then compounds 1 and 2 (each within the scatter of the next).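

In this assay, 4-chlorophenyl in place of 3-chlorophenyl gave a 1.3-fold higher number from compound 3 to compound 4 (0.12 log units; within the scatter), so this assay does not separate these two chlorophenyl groups on the carbon with a double bond to nitrogen. The gain seen with chloro is therefore not tied to the 3-chlorophenyl group alone: chloro in place of hydrogen gave a 3.3-fold lower number from compound 1 to compound 4 (0.51 log units; beyond the scatter) and chloro in place of methoxy gave a 5.5-fold lower number from compound 2 to compound 4 (0.74 log units; beyond the scatter) as well. No measurement shown here explains why these groups give these numbers.

On these data alone, it remains open whether other groups on the aromatic ring, such as bromo, nitrile or an amine, would match chloro or fall back towards hydrogen and methoxy. As far as these compounds go, all four compounds share one core, so the effect of a change there, such as a longer chain, also remains unknown.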